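Fluoro in place of methyl: compound 3 to compound 4

The source may report more compounds than this note shows. Statements on the series, on what has been measured and on what is new or still open speak of the compounds shown alone.

The series shares one core, shown in compound 1 `O=c1c2ccccc2[se]n1-c1nc(SCc2ccccc2)n[nH]1`, with a sulfur-linked arm that varies. In a functional assay on SMMC-7721 cells (Homo sapiens) for antiproliferative activity, read by CCK-8 assay, with a stated time of 48 h (a lower number here means a stronger inhibitor, a higher number a weaker inhibitor), compound 1 gives 32000 nM. Compound 2 `CCCCSc1n[nH]c(-n2[se]c3ccccc3c2=O)n1` carries the propyl variant of that arm. In this assay compound 2 gives 16800 nM. The step of a 1.9-fold lower number from compound 1 to compound 2 (0.28 log units; within the scatter) sits within the scatter. Compound 3 `Cc1ccc(CSc2n[nH]c(-n3[se]c4ccccc4c3=O)n2)cc1` bears the 4-methylbenzyl arm. For compound 3 this assay returns only a limit, > 50000 nM (the limit of > 50000 nM in this assay, at which 1 of the 3 values shown sits). Compound 3 thus stands at the weak end of the numbers shown: an at least 2.9-fold higher number from compound 2 to compound 3 (0.47 log units; beyond the scatter), whereas an at least 1.5-fold higher number from compound 1 to compound 3 (0.19 log units; that floor lies within the scatter). Compound 4 `O=c1c2ccccc2[se]n1-c1nc(SCc2ccc(F)cc2)n[nH]1` differs from compound 3 in one place: fluoro in place of methyl on an aromatic carbon. Among the compounds with values here, none of the measured steps exchanges fluoro for methyl; the nearest comparison is compound 1 against compound 3, hydrogen against methyl at the same aromatic carbon, and that step lies within the scatter. Within the data shown here, no measured step therefore argues for a move beyond the scatter in either direction in this assay, and the floor on compound 3 leaves room both ways. On that basis the expected step is an at least 1.2-fold lower number from compound 3 to compound 4 (0.09 log units; that floor lies within the scatter). In this assay compound 4 is estimated at 40000 nM, with a range from 15000 nM to 100000 nM. A limit rather than a number remains a real possibility for compound 4.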

Compound 4, half-maximal inhibitory concentration: 46100 nM
Compound 4: middle estimate off by 1.2-fold (0.06 log units), on the low side; the measured number falls inside the stated range.
By their numbers in this assay, from the lowest: compounds 2, 1 and 4 (each within the scatter of the next, the first and the last beyond it). At a limit, above all of these: compound 3.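

In this assay, fluoro on the aromatic carbon para to a large group returns a number, and that number does not separate from the unsubstituted arm of compound 1 (a 1.4-fold higher number from compound 1 to compound 4 (0.16 log units; within the scatter)). Against the propyl arm, the 4-fluorophenyl arm lies on the higher side (a 2.7-fold higher number from compound 2 to compound 4 (0.44 log units; beyond the scatter)), as the 4-methylphenyl arm does (an at least 2.9-fold higher number from compound 2 to compound 3 (0.47 log units; beyond the scatter)), so both substituted arms stand beyond the scatter from compound 2, whereas compound 1, with its unsubstituted arm, does not (a 1.9-fold lower number from compound 1 to compound 2 (0.28 log units; within the scatter)). The exchange of methyl for fluoro can be read only as a floor within the scatter (an at least 1.0-fold lower number from compound 3 to compound 4 (0.03 log units; that floor lies within the scatter)), since compound 3 holds a limit and not a number: the limit of > 50000 nM in this assay, at which 1 of the 4 values shown sits.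

From the compounds shown here alone, whether fluoro and methyl truly differ at this carbon stays open, as does whether an amine or a carboxylic acid there would bring the number near that of compound 2. Also open, going by these compounds, is how a longer chain in place of the propyl would stand against compound 2 in this assay.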